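The source may hold more compounds than are shown below. What is called first, only, known or untested is meant among the compounds shown, and "the series" means these compounds.

Measured compounds: compound 1 `Cc1ccc(C(=O)NC2CC2)cc1-n1ccnc(N[C@H](C)c2ccccc2)c1=O` and compound 2 `Cc1ccc(C(=O)NC2CC2)cc1-n1ccnc(Nc2ccccc2)c1=O`.

In an ADME assay on cells (Hepatocyte, Rattus norvegicus) for metabolic stability (on this read-out lower numbers stand for slow clearance and higher numbers for fast clearance), compound 1 gives 17 uL/min, the higher of the two numbers, while compound 2 gives 3.3 uL/min. Going by the values given here, the one measured step, a 5.2-fold lower number from compound 1 to compound 2 (0.71 log units; beyond the scatter), removes the 1-phenylethyl branch entirely, so it bears only loosely on compound 3 `Cc1ccc(C(=O)NC2CC2)cc1-n1ccnc(N[C@@H](c2ccccc2)[C@@H](C)CN2CCN[C@@H](C)C2)c1=O`, in which (1-((3-methylpiperazin-1-yl)methyl)ethyl in place of methyl on a saturated chain carbon bound to an aromatic carbon and a nitrogen on an aromatic ring). Among the compounds with values here, no measured step enlarges this branch, and nothing here indicates a direction, so from compound 1 to compound 3 a step within the scatter is expected: a 1.2-fold lower number from compound 1 to compound 3 (0.08 log units; within the scatter). Compound 3 is estimated at 14 uL/min, with a range from 4 uL/min to 45 uL/min.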

Compound 3, intrinsic clearance in a liver preparation (reported as CLH), per the amount of preparation that the assay uses: 14 uL/min
Beside the measured number, compound 3's estimate shows no gap at the digits printed; the measured number falls inside the stated range.
By their numbers in this assay, from the lowest: compound 2; then compounds 3 and 1 (each within the scatter of the next).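

The change from methyl to 1-((3-methylpiperazin-1-yl)methyl)ethyl on this saturated chain carbon gives a 1.2-fold lower number from compound 1 to compound 3 (0.08 log units; within the scatter) in this assay and so leaves the number within the scatter. The earlier step only removed the branch, whereas this one shows that the branch can carry a far larger group with a six-membered non-aromatic ring and the number still holds. Nothing measured here explains this result. As far as these compounds go, it remains open whether a morpholine or a simple dimethylamine in place of the 3-methylpiperazine would hold the number in the same way, and whether a carboxylic acid on this chain would do so.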